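This account rests on a few compounds, and the source may have more. Where it says the series, first, only, none or still open, it means among the compounds named here.

The compounds measured in an ADME assay on Huh-7 cells (Homo sapiens) for cytotoxicity (a lower number here means that less compound is tolerated, a higher number that more compound is tolerated), so far:

Compound 1 `Cc1ccccc1-c1nn(-c2ccc(F)cc2F)cc1CNCCN1CCCCC1`: > 20000 nM
Compound 2 `Cc1ccc(-c2nn(-c3ccc(F)cc3F)cc2CNCCN2CCN(C)CC2)cc1`: > 20000 nM
Compound 3 `COc1ccc(-n2cc(CNCCN3CCN(C)CC3)c(-c3ccccc3C)n2)cc1`: > 20000 nM

Compound 2 does not stand at a number in this assay but at a limit: its value of > 20000 nM marks the limit of the assay, not a measured concentration. Within the data shown here, the same is true of compound 1 and of compound 3, so that the limit of > 20000 nM in this assay, at which 3 of the 3 values shown sit, describes every result at hand; none of the three gives a number from which a step could be computed, and no step between measured compounds can be given.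

Compound 4 `CN1CCN(CCNCc2cn(-c3ccc(F)cc3F)nc2-c2ccc(S(=O)(=O)N(C)C)cc2)CC1` has not yet been measured in this assay. It differs from compound 2 in one place, (dimethylsulfamoyl in place of methyl on an aromatic carbon). Among the measured compounds shown here, as no measured step is available, there is no ground for expecting the cytotoxic concentration to shift beyond the scatter in either direction; the expectation is simply that compound 4, like compound 2, will again sit at the limit. Compound 4 is thus estimated at 25000 nM, with a range from 8000 nM to 80000 nM. This estimate means an expected step that the limit leaves unreadable from compound 2 to compound 4.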

Compound 4, half-maximal cytotoxic concentration: > 20000 nM
Compound 4: only a limit was reported; the forecaster's own chance of this, stated with the estimate: 80%; the middle value is on the limit's open side.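

In this assay compound 4 gives > 20000 nM, a limit and not a number. Compound 2 also stands at a limit, so no step between compound 2 and compound 4 can be read: the limit of > 20000 nM in this assay, at which 4 of the 4 values shown sit. The compounds shown leave open at what concentration any of them becomes cytotoxic.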